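The compounds below may be only part of what the source reports. "The series", "measured", "known", "first", "only" and "open" are said of these compounds alone.

Measured compounds

Compound 1, `COc1cc(/C=C\c2ccc(N(C)C)c([N+](=O)[O-])c2)cc(OC)c1OC`: > 5000 nM, a limit of the assay
Compound 2, `COc1cc(/C=C\c2ccc(N(C)C)c(N)c2)cc(OC)c1OC`: 4 nM
Compound 3, `COc1cc(/C=C/c2ccc3ccccc3c2)cc([N+](=O)[O-])c1OC`: > 10000 nM, a limit of the assay

Notes

In a functional assay on A549 cells (Homo sapiens) for inhibition (on this read-out lower numbers stand for stronger inhibition and higher numbers for weaker inhibition), compound 1 gives > 5000 nM; this is a limit of the assay and not a number. Compound 2 gives 4 nM in this assay. The change between them is amino in place of nitro on an aromatic carbon and the step is an at least 1200-fold lower number from compound 1 to compound 2 (3.09 log units; beyond the scatter). That only a limit stands for compound 1 is seen in the limit of > 5000 nM in this assay, at which 1 of the 3 values shown sits.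

In this assay compound 3 gives > 10000 nM, again a limit of the assay rather than a number, as recorded in the limit of > 10000 nM in this assay, at which 1 of the 3 values shown sits. The difference between the core of compound 3 and the core of compound 1 is not broken down here.

Compound 4, `COc1cc(/C=C/c2ccc3ccccc3c2)cc(N)c1OC`, is not yet measured in this assay. It differs from compound 3 by amino in place of nitro on an aromatic carbon. This is the same kind of change as that from compound 1 to compound 2, not the same change: in compound 3 the carbon is ortho to a methoxy group and meta to a methoxy group, whereas in compound 1 it is ortho to a dimethylamino group; both are meta to a large group.

For compound 4 the expected value in this assay is 300 nM. That expectation rests on an at least 1200-fold lower number from compound 1 to compound 2 (3.09 log units; beyond the scatter) and on the limit recorded for compound 3. The step expected is an at least 33-fold lower number from compound 3 to compound 4 (1.52 log units; beyond the scatter). The range is wide, since the starting point is a limit and the surroundings of the changed carbon differ.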

Compound 4, half-maximal inhibitory concentration: 2150 nM
The estimate for compound 4 lay 7.2-fold (0.86 log units) below the measured number, within the range that was stated.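

In this assay, amino in place of nitro on an aromatic carbon also gives a lower number on the second core, with an at least 4.6-fold lower number from compound 3 to compound 4 (0.66 log units; beyond the scatter), so the direction of the step seen on the core of compound 1 recurs on the core of compound 3, where the changed carbon is ortho to a methoxy group and meta to a methoxy group. This shows only that the direction is shared by these two pairs of compounds, and it gives no general rule for the series. It does not show whether the size of the step carries over from one core to the other, and the comparison of the two steps stays unresolved: the same change on two cores in this assay, an at least 1200-fold lower number (3.09 log units; beyond the scatter) from compound 1 to compound 2 and an at least 4.6-fold lower number (0.66 log units; beyond the scatter) from compound 3 to compound 4; the limit leaves it open whether they differ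

Left open is how a hydroxyl group, a methylamino group or an acetamide on the same aromatic carbon would read in this assay on either core, as the compounds shown hold only nitro and amino there. Also open, on these data alone, is whether the step survives on the core of compound 3 with an ethoxy group or a hydrogen in place of the methoxy group ortho to the changed carbon.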